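Chain extension on the fluorinated core of compound 3

A few compounds are considered here, and "the series" means these few. Any claim that something is new, unique, unknown or untested is made for them only; others in the source may bear on it.

Compound 1 `Nc1nc(NCCCCc2ccccc2)nc(-c2ccccc2CO)n1`: 5.52
Compound 2 `COc1ccccc1CNc1nc(N)nc(-c2c(F)cccc2CO)n1`: 4.11
Compound 3 `Nc1nc(NCCCc2ccccc2)nc(-c2c(F)cccc2CO)n1`: 4.47

In a functional assay on cells for positive allosteric modulation of G-protein coupled receptor 68 (Homo sapiens), read by a luciferase reporter and cAMP accumulation, with a stated time of 30 min, at pH 6.8 and pH 8.3, in the presence of a further agent that is not named here (on this read-out higher numbers stand for higher potency (the scale is a negative logarithm) and lower numbers for lower potency), compound 3 stands second of the three measured compounds, beyond the scatter from both neighbours: compound 2 lies lower and compound 1 lies higher. Compound 4 `Nc1nc(NCCCCc2ccccc2)nc(-c2c(F)cccc2CO)n1` is reached from compound 3 by one change, (benzyl in place of phenyl on a saturated chain carbon, three bonds along the chain from a nitrogen on an aromatic ring). Among the measured compounds shown here, the only measured step that bears on it is the chain lengthening a number 0.36 log units higher from compound 2 to compound 3 (beyond the scatter), a modest gain. For the measured compounds named here, compound 1, which carries the longer chain without the fluorine, sits well above compound 3, but no single step links them. On this basis a modest rise is expected for compound 4, estimated at 5 within 4.4 to 5.6, a step of a number 0.53 log units higher from compound 3 to compound 4 (beyond the scatter).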

Compound 4, negative logarithm of the antagonist equilibrium constant: 4.04
Compound 4: the middle estimate sits 0.96 log units above what was measured; the measured number lies below the stated range.
By their numbers in this assay, from the lowest: compounds 4 and 2 (each within the scatter of the next); then compound 3; then compound 1.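

In this assay, the change of phenyl to benzyl at this position gives a number 0.43 log units lower from compound 3 to compound 4 (beyond the scatter), so on the fluoro-bearing core the 3-phenylpropyl chain does not continue the earlier gain. Replacing 2-methoxyphenyl with 3-phenylpropyl gives a number 0.07 log units lower from compound 2 to compound 4 (within the scatter), while fluoro in place of hydrogen gives a number 1.48 log units lower from compound 1 to compound 4 (beyond the scatter), the largest single step seen so far. Nothing measured here explains this loss. Still open, as far as these compounds go, is whether a longer chain or a terminal amine would recover potency on this core.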